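This account rests on a few compounds, and the source may have more. Where it says the series, first, only, none or still open, it means among the compounds named here.

Measured so far in a functional assay on A2780 cells (Homo sapiens) for inhibition, with a stated time of 72 h, tested at 10 uM; on this read-out lower numbers stand for less inhibition of growth and higher numbers for more inhibition of growth at the one concentration tested:
compound 1 `CCC1(CC)CC(C)(C)Oc2ccc(NC(=S)Nc3ccc([N+](=O)[O-])cc3)cc21` — 95.7%
compound 2 `CCC1(CC)CC(C)(C)c2cc(NC(=O)Nc3ccc(C(F)(F)F)cc3)ccc2O1` — 92.4%
compound 3 `CCC1(CC)CC(C)(C)Oc2ccc(NC(=S)Nc3ccc(C(F)(F)F)cc3)cc21` — 11.8%

Compound 3 and compound 1 differ in one place only: nitro in place of trifluoromethyl on an aromatic carbon. In this assay that single change produced a number 83.9 percentage points higher from compound 3 to compound 1 (beyond the scatter). Compound 2 carries the same trifluoromethyl-bearing ring as compound 3, but the two cores differ; that difference between the cores is not broken down here.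

Compound 4 `CCC1(CC)CC(C)(C)c2cc(NC(=O)Nc3ccc([N+](=O)[O-])cc3)ccc2O1` has not yet been measured. It arises from compound 2 by nitro in place of trifluoromethyl on an aromatic carbon, and the place of the change is the same in every word, so this is the same change already seen between compound 3 and compound 1. Compound 2, however, already gives 92.4%, leaving little room upward, so the step from compound 2 to compound 4 is expected to be a number 3.6 percentage points higher from compound 2 to compound 4 (within the scatter), far smaller than the earlier one. Compound 4 is therefore estimated at 96%, between 86% and 100%.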

Compound 4, percent growth inhibition at one concentration: 93.2%
Compound 4: middle estimate off by 2.8 percentage points, on the high side, within the range that was stated.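

In this assay, putting nitro in place of trifluoromethyl gives a number 0.8 percentage points higher from compound 2 to compound 4 (within the scatter). The size of this change therefore does not carry over from one core to the other: the same change on two cores in this assay, a number 83.9 percentage points higher (beyond the scatter) from compound 3 to compound 1 and a number 0.8 percentage points higher (within the scatter) from compound 2 to compound 4, 83.1 percentage points apart, beyond the scatter of two such steps. With compound 2 at 92.4% there is little room upward, so a single concentration cannot tell whether the change truly does nothing on this core or a gain stays hidden, and the two pairs do not show what in the cores sets them apart.

The compounds shown leave open how another group at this place, such as a nitrile or an amine, would behave on either core. Also open, going by these compounds, is how these pairs would compare at lower concentrations.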